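From phenyl to 4-methylphenyl in compound 4

The compounds below may be only part of what the source reports. "The series", "measured", "known", "first", "only" and "open" are said of these compounds alone.

Values in a functional assay on MCF7 cells (Homo sapiens) for inhibition; a lower number here means a stronger inhibitor, a higher number a weaker inhibitor:
- compound 1 `O=C(CC(CC(=O)NC1Cc2ccccc2C1)c1ccc(Cl)cc1)NCCN1CCCCC1`: 35500 nM
- compound 2 `O=C(CC(CC(=O)NC1Cc2ccccc2C1)c1ccccc1)NCCN1CCCCC1`: > 100000 nM (a limit)
- compound 3 `CCN(CC)CCNC(=O)CC(CC(=O)NC1Cc2ccccc2C1)c1ccccc1`: > 100000 nM (a limit)

Compound 2 gives > 100000 nM, which is a limit and not a number. Compound 3 sits at the same limit.

Compound 4 `Cc1ccc(C(CC(=O)NCCN2CCCCC2)CC(=O)NC2Cc3ccccc3C2)cc1` differs from compound 2 by methyl in place of hydrogen on an aromatic carbon. The closest measured change is an at least 2.8-fold higher number from compound 1 to compound 2 (0.44 log units; beyond the scatter), with hydrogen in place of chloro on an aromatic carbon. The other measured change, a step that the two limits leave unreadable from compound 2 to compound 3, concerns a different group and does not bear on this one. Read in reverse, the step to compound 1 leads to the expectation of a modest move toward a lower number in this assay, though another limit remains possible. The expected change is an at least 1.4-fold lower number from compound 2 to compound 4 (0.15 log units; that floor lies within the scatter). For compound 4 the estimate is 70000 nM, with an expected range of 30000 nM to 150000 nM.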

Compound 4, half-maximal inhibitory concentration: > 100000 nM
Compound 4 was reported as a limit; the forecaster's own chance of this, stated with the estimate: 40%; middle value at least 1.4-fold (0.15 log units) away from the limit.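

In this assay, methyl does not match chloro at this position on the aromatic ring, and the change from one to the other gives an at least 2.8-fold higher number from compound 1 to compound 4 (0.44 log units; beyond the scatter). Compound 4 joins the compounds held at the assay's limit: the limit of > 100000 nM in this assay, at which 3 of the 4 values shown sit. The step from hydrogen to methyl, like the step between the two side-chain amines, cannot be read, so any effect of methyl remains hidden.

Open, on these data alone, is whether bromo, methoxy or an amine at this position would give a readable value, and whether chloro would do so with diethylamino in place of piperidin-1-yl.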